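A third benzyl variant near the assay limit

A few compounds are considered here, and "the series" means these few. Any claim that something is new, unique, unknown or untested is made for them only; others in the source may bear on it.

Compound 1 (`OC[C@H]1O[C@@H](n2cnc3c(NCc4ccccc4Br)ncnc32)[C@H](O)[C@@H]1O`) > 166000 nM (a limit)
Compound 2 (`OC[C@H]1O[C@@H](n2cnc3c(NCc4cccc(Br)c4)ncnc32)[C@H](O)[C@@H]1O`) > 166000 nM (a limit)

In a functional assay on HOS cells (Homo sapiens) for antiproliferative activity, with a stated time of 72 h (on this read-out higher numbers stand for weaker inhibition and lower numbers for stronger inhibition), compound 2 stands at > 166000 nM, which is a limit and not a number. Compound 3 (`Cc1ccc(CNc2ncnc3c2ncn3[C@@H]2O[C@H](CO)[C@@H](O)[C@H]2O)cc1`) is not yet measured and differs from it by 4-methylphenyl in place of 3-bromophenyl on a saturated chain carbon bound to a nitrogen on an aromatic ring. Going by the values given here, the one measured step that bears on this, a step that the two limits leave unreadable from compound 1 to compound 2, gives no size to carry over. The data so far consist only of the limit of > 166000 nM in this assay, at which 2 of the 2 values shown sit. The expected step is an at least 1.5-fold lower number from compound 2 to compound 3 (0.17 log units; that floor lies within the scatter), and its size and direction remain weakly supported. Compound 3 is estimated at 110000 nM, with an expected range from 25000 nM to 166000 nM, and may well report only a limit.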

Compound 3, half-maximal inhibitory concentration: > 166000 nM
Compound 3: no number, only a limit; the forecaster's own chance of this, stated with the estimate: 65%; middle value at least 1.5-fold (0.17 log units) away from the limit.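

Going by these compounds alone, compound 1, compound 2 and compound 3 each report only a limit in this assay, so no step among them can be read: the limit of > 166000 nM in this assay, at which 3 of the 3 values shown sit. The compounds shown leave open whether 2-bromophenyl, 3-bromophenyl and 4-methylphenyl differ at all in this assay.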